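Trifluoromethyl at the tail end of a long chain

A few compounds are considered here, and "the series" means these few. Any claim that something is new, unique, unknown or untested is made for them only; others in the source may bear on it.

Compound 1 `CCCCCCCCCCCCCCc1ccccc1C(SCCC(=O)O)SCCC(=O)O` carries a straight saturated chain on its core. In an assay on membranes from lung (Cavia porcellus) for binding affinity to cysteinyl leukotriene receptor (Homo sapiens) (on this read-out lower numbers stand for stronger inhibition and higher numbers for weaker inhibition), compound 1 gives 1250 nM, the highest of the two numbers seen so far. Compound 2 `CCCCCCCCCCc1ccccc1C(SCCC(=O)O)SCCC(=O)O` gives 1180 nM in this assay, and the step of a 1.1-fold lower number from compound 1 to compound 2 (0.03 log units; within the scatter) shows that shortening the chain far from the ring leaves the number essentially unchanged.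

Compound 3 `O=C(O)CCSC(SCCC(=O)O)c1ccccc1CCCCCCCCCCCC(F)(F)F` differs from compound 1 by trifluoromethyl in place of propyl on a saturated chain carbon, ten or more bonds along the chain from an aromatic carbon. Among the measured compounds shown here, this alters the far end of the same chain that was shortened in compound 2, and that change stayed within the scatter; no measured step yet shows what fluorine at this position does. The expectation for this assay is therefore a step of a 1.0-fold lower number from compound 1 to compound 3 (0.02 log units; within the scatter), with no direction beyond the scatter. Compound 3 is estimated at 1200 nM, in the range 500 nM to 3000 nM.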

Compound 3, inhibition constant: 147 nM
For compound 3 the middle estimate is 8.2-fold (0.91 log units) above the measured one; the whole stated range lies above it.
By their numbers in this assay, from the lowest: compound 3; then compounds 2 and 1 (each within the scatter of the next).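

In this assay, the far end of the chain turns out to matter after all: trifluoromethyl in place of propyl gives an 8.5-fold lower number from compound 1 to compound 3 (0.93 log units; beyond the scatter), a change that lies beyond the scatter, whereas shortening the chain in compound 2 did not. The comparison with the shorter chain reads much the same, with an 8.0-fold lower number from compound 2 to compound 3 (0.90 log units; beyond the scatter), so among these three compounds only the one ending in trifluoromethyl stands apart. Nothing measured here says why this end group lowers the number.

As far as these compounds go, it remains open whether trifluoromethyl is special at this place, or whether another end group, such as a single fluorine, a chlorine or a hydroxyl, would do the same. Also open, from the compounds shown here alone, is how much the chain length matters once trifluoromethyl sits at its end, as a shorter or a longer chain carrying this group could give a different number.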